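A few compounds are considered here, and "the series" means these few. Any claim that something is new, unique, unknown or untested is made for them only; others in the source may bear on it.

In a functional assay on SMMC-7721 cells (Homo sapiens) for inhibition, read by MTT assay, with a stated time of 48 h (a lower number here means a stronger inhibitor, a higher number a weaker inhibitor), compound 3 `CC(C)c1cccc(NC(=O)Nc2cccc(-c3cccc4[nH]nc(N)c34)c2)c1` gives 280 nM, compound 1 `Cc1ccc(NC(=O)Nc2cccc(-c3cccc4[nH]nc(N)c34)c2)cc1Cl` gives 510 nM and compound 2 `Nc1n[nH]c2cccc(-c3cccc(NC(=O)Nc4ccc(Cl)cc4Cl)c3)c12` gives 1900 nM. Compound 3 thus stands within the scatter of compound 1, with a 1.8-fold lower number from compound 1 to compound 3 (0.26 log units; within the scatter), and well clear of compound 2, with a 6.8-fold lower number from compound 2 to compound 3 (0.83 log units; beyond the scatter). Compound 4 `Nc1n[nH]c2cccc(-c3cccc(NC(=O)Nc4ccccc4F)c3)c12` carries 2-fluorophenyl in place of 3-isopropylphenyl on an amide-type nitrogen. The measured compounds differ only in this group, and a 3.7-fold higher number from compound 1 to compound 2 (0.57 log units; beyond the scatter) also shows that changing it can move the number beyond the scatter. No measured replacement of 3-isopropylphenyl gives a lower number beyond the scatter, so a modest rise is expected in this assay, a 2.9-fold higher number from compound 3 to compound 4 (0.46 log units; beyond the scatter). For compound 4 the estimate is 800 nM, with an expected range of 250 nM to 2500 nM.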

Compound 4, half-maximal inhibitory concentration: 2360 nM
The estimate for compound 4 lay 3.0-fold (0.47 log units) below the measured number; measured number inside the range.
By their numbers in this assay, from the lowest: compounds 3 and 1 (each within the scatter of the next); then compounds 2 and 4 (each within the scatter of the next).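

Moving from 3-isopropylphenyl to 2-fluorophenyl costs more in this assay (an 8.4-fold higher number from compound 3 to compound 4 (0.93 log units; beyond the scatter)) than the opening estimate allowed for, and 3-chloro-4-methylphenyl also gives way to 2-fluorophenyl beyond the scatter (a 4.6-fold higher number from compound 1 to compound 4 (0.67 log units; beyond the scatter)). The smaller 2-fluorophenyl group matches 2,4-dichlorophenyl (a 1.2-fold higher number from compound 2 to compound 4 (0.09 log units; within the scatter)), so among these four compounds the two groups with a halogen at the 2-position of the ring sit together, apart from compound 1 and compound 3. Nothing available explains these differences. Going by these compounds, whether that halogen itself matters remains open: 3-fluorophenyl and 2-methylphenyl groups on the same amide-type nitrogen would separate its identity from its place.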